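The compounds below may be only part of what the source reports. "The series", "measured", "known", "first", "only" and "open" are said of these compounds alone.

Measured in a functional assay on MiaPaCa cells (Homo sapiens) for antiproliferative activity, read by sulforhodamine B assay, with a stated time of 48 h; a lower number here means a stronger inhibitor of growth, a higher number a weaker inhibitor of growth:
Compound 1 `Cc1ccc(-c2cn(CCCN3C(=O)COc4ccccc43)nn2)cc1`: > 100000 nM, a limit.
Compound 2 `CCCCCc1ccc(-c2cn(CCCN3C(=O)COc4ccccc43)nn2)cc1`: > 100000 nM, a limit.
Compound 3 `COc1ccc2cc(-c3cn(CCCN4C(=O)COc5ccccc54)nn3)ccc2c1`: > 100000 nM, a limit.

Compound 1 has no number in this series, only a limit, and the two other measured compounds are in the same position. The next compound is compound 4 `O=C1COc2ccccc2N1CCCn1cc(-c2ccccn2)nn1`, with the change pyridin-2-yl in place of 4-methylphenyl on an aromatic carbon of the five-membered aromatic ring with 3 nitrogen. Among the measured compounds shown here, the one measured step between compounds differing in one place is a step that the two limits leave unreadable from compound 1 to compound 2. It gives no size to carry over, and it lies at a different place from the change in compound 4. For the measured compounds named here, the only guide is the limit of > 100000 nM in this assay, at which 3 of the 3 values shown sit. Going by the values given here, no step of any readable size is therefore expected in this assay, and no direction can be assigned. Compound 4 is expected to sit at the same limit. The estimated step is a number no higher from compound 1 to compound 4 (the limit leaves the size open). For compound 4 the estimated value is 100000 nM, with an expected range of 25000 nM to 200000 nM.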

Compound 4, concentration for 50% growth inhibition: 5800 nM
Estimate against measurement, compound 4: 17-fold (1.24 log units) above, and the stated range ends above it.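

In this assay, pyridin-2-yl in place of 4-methylphenyl on the aromatic carbon of the five-membered aromatic ring with 3 nitrogen gives an at least 17-fold lower number from compound 1 to compound 4 (1.23 log units; beyond the scatter). This place on the shared core can therefore move the read-out, which compounds 1, 2 and 3 could not show, as each stops at a limit: the limit of > 100000 nM in this assay, at which 3 of the 4 values shown sit. Compound 4 is the only compound shown with a number, and its group is also the only one shown at this place with a ring nitrogen rather than an aromatic ring of carbon only.

The step swaps the whole group, so it does not separate the ring nitrogen from the loss of the methyl group; an unsubstituted phenyl would bear on that. On these data alone, whether the placement of the ring nitrogen matters also stays open, and pyridin-3-yl or pyridin-4-yl would address it.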